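Purine benzamide series: butyl for cyclopentyl on the ring nitrogen

A few compounds are considered here, and "the series" means these few. Any claim that something is new, unique, unknown or untested is made for them only; others in the source may bear on it.

Compound 1 `CN1CCN(c2nc(Cl)nc3c2ncn3Cc2ccc(C(=O)Nc3ccccc3N)cc2)CC1` gives 6160 nM in a functional assay on NCI-H460 cells (Homo sapiens) for antiproliferative activity, read by CCK-8 assay, with a stated time of 72 h; on this read-out higher numbers stand for weaker inhibition and lower numbers for stronger inhibition.
Compound 2 `Nc1ccccc1NC(=O)c1ccc(COCNc2nc(Nc3ccccc3)c3ncn(C4CCCC4)c3n2)cc1` gives 18100 nM in this assay.
Compound 3 `CC1CCN(c2nc(Cl)nc3c2ncn3Cc2ccc(C(=O)Nc3ccccc3N)cc2)CC1` gives 7400 nM in this assay.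

Compound 2 gives the highest of the three numbers in this assay; compound 3 lies nearest and compound 1 furthest, both differences beyond the scatter. Among the measured compounds shown here, the only measured single-point step, a 1.2-fold higher number from compound 1 to compound 3 (0.08 log units; within the scatter), concerns a group on an aromatic carbon of the shared core of compound 1 and compound 3 and does not touch the substituent on the aromatic nitrogen.

Compound 4 `CCCCn1cnc2c(Nc3ccccc3)nc(NCOCc3ccc(C(=O)Nc4ccccc4N)cc3)nc21` differs from compound 2 by butyl in place of cyclopentyl on an aromatic nitrogen. For the measured compounds named here, no measured pair probes a change at this position, so no step beyond the scatter is expected in this assay in either direction. Compound 4 is therefore expected to give about 18000 nM, within 7000 nM to 45000 nM. The expected step is a 1.0-fold lower number from compound 2 to compound 4 (0.00 log units; within the scatter), within the scatter.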

Compound 4, half-maximal inhibitory concentration: 8780 nM
Compound 4: middle estimate off by 2.1-fold (0.31 log units), on the high side, and the stated range covers the measured number.
By their numbers in this assay, from the lowest: compounds 1, 3 and 4 (each within the scatter of the next); then compound 2.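

In this assay, among the compounds shown here, the substituent on the aromatic nitrogen gives the first single-point step beyond the scatter in this set, a modest one: a 2.1-fold lower number from compound 2 to compound 4 (0.31 log units; beyond the scatter) with butyl in place of cyclopentyl. The earlier step, at a group on an aromatic carbon of a different core, stayed within the scatter, so this nitrogen is the only position here where a change registers. No supporting data bear on this shift.

This single pair does not separate loss of the ring from loss of one carbon. Cyclobutyl or pentyl on this nitrogen would separate the two, and an amine-bearing chain there remains open.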